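The compounds below may be only part of what the source reports. "The series", "measured", "known", "first", "only" and "open" are said of these compounds alone.

Compound 1, `O=C(O)[C@H](CO)NC(=O)[C@H]1C[C@H](O)CN1`, gives > 12 h in an ADME assay for metabolic stability, read by HPLC, in simulated intestinal fluid, with a stated time of 12 h, at pH 6.8 (a higher number here means that the compound lasts longer, a lower number that the compound disappears faster), a limit of this assay.
Compound 2, `O=C(O)[C@H](CO)NC(=O)[C@H]1C[C@@H](O)CN1`, gives > 12 h in this assay, again a limit.
Compound 3, `O=C(O)[C@H](CO)NC(=O)[C@@H]1C[C@H](O)CN1`, gives > 12 h in this assay, also a limit.

Compound 1 therefore stands at a limit of this assay rather than at a measured number, and the same holds for the other two compounds, as the limit of > 12 h in this assay, at which 3 of the 3 values shown sit, records. The unmeasured compound 4, `O=C(O)[C@H](CO)NC(=O)[C@@H]1C[C@@H](O)CN1`, differs from compound 1 as follows: the two compounds have the same atoms and bonds and differ only in configuration as drawn: 2 of 3 stereo elements differ; a stereocentre at a saturated ring carbon is drawn R in compound 1 and S in compound 4; a stereocentre at a saturated ring carbon is drawn S in compound 1 and R in compound 4.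

For the measured compounds named here, three measured steps bear on this change. The step that the two limits leave unreadable from compound 1 to compound 2 and the step that the two limits leave unreadable from compound 1 to compound 3 each turn one stereocentre at a saturated ring carbon, and the step that the two limits leave unreadable from compound 2 to compound 3 turns two of them; because of the fact that compounds 1 and 2 differ only in the configuration as drawn, the fact that compounds 1 and 3 differ only in the configuration as drawn and the fact that compounds 2 and 3 differ only in the configuration as drawn show every pair differing only in configuration as drawn, none of these steps gave a readable size. Going by the values given here, nothing among the measured compounds shows that turning two stereocentres at saturated ring carbons brings the half-life below the limit.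

Compound 4 is therefore expected to reach the limit as well, the expected step of a number no higher from compound 1 to compound 4 (the limit leaves the size open) being none beyond the scatter, with an estimate of 12 h and a range from 8 h to 12 h.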

Compound 4, half-life: > 12 h
Compound 4 gave a limit, no number; the forecaster's own chance of this, stated with the estimate: 85%; the middle value sits exactly at the limit.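

For the compounds shown here, compound 4 stands at a limit of this assay, as do compound 1, compound 2 and compound 3, so no step from compound 4 to any of them can be read. The compounds shown leave open whether configuration as drawn changes the half-life at all: the limit of > 12 h in this assay, at which 4 of the 4 values shown sit.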